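The source may hold more compounds than are shown below. What is called first, only, known or untested is meant among the compounds shown, and "the series" means these compounds.

Measured so far in a functional assay on SF-295 cells (Homo sapiens) for antiproliferative activity, with a stated time of 48 h; a higher number here means a weaker inhibitor of growth, a lower number a stronger inhibitor of growth:

Compound 1 `Cc1cc(O)c(C2=NN(c3ccc(S(N)(=O)=O)cc3)C(c3ccccc3O)C2)cc1Cl` gives 3670 nM.
Compound 2 `Cc1cc(O)c(C2=NN(c3ccc(S(N)(=O)=O)cc3)C(/C=C/c3ccccc3)C2)cc1Cl` gives 11900 nM.

Going by the values given here, of the two numbers in this assay, compound 2 stands at the higher one, and the only measured step is the one that leads to it: a 3.2-fold higher number from compound 1 to compound 2 (0.51 log units; beyond the scatter), where 2-phenylethenyl took the place of 2-hydroxyphenyl on a saturated ring carbon. Compound 3 `COc1ccc(C2CC(c3cc(Cl)c(C)cc3O)=NN2c2ccc(S(N)(=O)=O)cc2)cc1OC` has not yet been tested in this assay. It differs from compound 2 in one place: 3,4-dimethoxyphenyl in place of 2-phenylethenyl on a saturated ring carbon. Among the compounds with values here, the change thus puts an aromatic ring back where compound 2 carries a 2-phenylethenyl group, so the one step that bears on it is the step from compound 1 to compound 2, which raised the number beyond the scatter; compound 3 differs from compound 1 too, since its ring is a 3,4-dimethoxyphenyl rather than a 2-hydroxyphenyl, so that step is a guide only in direction. A downward step of modest size is expected, a 2.2-fold lower number from compound 2 to compound 3 (0.34 log units; beyond the scatter), though it may fall close to the scatter. Compound 3 is therefore estimated at 5500 nM in this assay, with a likely range from 2200 nM to 14000 nM.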

Compound 3, concentration for total growth inhibition: 6240 nM
Beside the measured number, compound 3's estimate is 1.1-fold (0.05 log units) below it; the range from low to high includes it.
By their numbers in this assay, from the lowest: compounds 1, 3 and 2 (each within the scatter of the next, the first and the last beyond it).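

In this assay, 3,4-dimethoxyphenyl on the saturated ring carbon next to the ring nitrogen gives a result that cannot be separated from either group tested there earlier: the comparison with 2-phenylethenyl shows a 1.9-fold lower number from compound 2 to compound 3 (0.28 log units; within the scatter), and the comparison with 2-hydroxyphenyl shows a 1.7-fold higher number from compound 1 to compound 3 (0.23 log units; within the scatter). Going by these compounds alone, the earlier compounds showed only that these two groups lie apart, with a 3.2-fold higher number from compound 1 to compound 2 (0.51 log units; beyond the scatter), and compound 3 now bridges that gap, so the three compounds do not divide into two clear levels even though the entering group carries two hydrogen-bond acceptors and a larger heavy-atom count than 2-phenylethenyl. No measurement is available that would explain why these three groups give such similar or differing numbers at this position.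

Going by these compounds, whether a plain phenyl, a phenyl ring bearing an amine or a carboxylic acid, or a saturated 2-phenylethyl chain would stay within this same narrow range remains open. The compounds shown also leave open whether either methoxy group of the 3,4-dimethoxyphenyl matters on its own, and whether the same picture would hold with another group in place of the 4-sulfamoylphenyl.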